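The source may report more compounds than this note shows. Statements on the series, on what has been measured and on what is new or still open speak of the compounds shown alone.

Three compounds on the shared core of compound 1 `CCN(CC)c1ccc2cc(C(=O)c3ccc(N4CCN(C(=O)CN5CCN(S(=O)(=O)C6CC6)CC5)CC4)cc3)oc2c1` differ only in the group carried on an amine nitrogen in a ring. In a functional assay on SGC-7901 cells (Homo sapiens) for cytotoxicity, read by MTT assay, with a stated time of 48 h (on this read-out higher numbers stand for weaker inhibition and lower numbers for stronger inhibition), compound 1 gives 15300 nM. Compound 2 `C#CCN1CCN(CC(=O)N2CCN(c3ccc(C(=O)c4cc5ccc(N(CC)CC)cc5o4)cc3)CC2)CC1` gives 20100 nM in this assay, and compound 3 `CCN(CC)c1ccc2cc(C(=O)c3ccc(N4CCN(C(=O)CN5CCN(Cc6ccc(C#N)cc6)CC5)CC4)cc3)oc2c1` gives 26300 nM. Compound 1 shows the lowest of the three numbers, yet the separation is slight: a 1.3-fold higher number from compound 1 to compound 2 (0.12 log units; within the scatter) and a 1.7-fold higher number from compound 1 to compound 3 (0.24 log units; within the scatter) both fall within the scatter, as does a 1.3-fold higher number from compound 2 to compound 3 (0.12 log units; within the scatter), so no ranking among the three can be claimed.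

Compound 4 `CCN(CC)c1ccc2cc(C(=O)c3ccc(N4CCN(C(=O)CN5CCN(CC(C)=O)CC5)CC4)cc3)oc2c1` carries 2-oxopropyl in place of cyclopropylsulfonyl on an amine nitrogen in a ring. The two measured steps that bear on this are the exchanges at the same ring nitrogen leading from compound 1 to compound 2 and from compound 1 to compound 3; each swapped cyclopropylsulfonyl for a different group and neither moved the number beyond the scatter. The step of a 1.2-fold higher number from compound 1 to compound 4 (0.07 log units; within the scatter) is therefore expected to remain within the scatter, with no clear direction. Compound 4 is estimated to give 18000 nM in this assay, in a range of 9000 nM to 36000 nM.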

Compound 4, half-maximal inhibitory concentration: 2210 nM
Estimate against measurement, compound 4: 8.1-fold (0.91 log units) above; measured number outside the range, below it.
By their numbers in this assay, from the lowest: compound 4; then compounds 1, 2 and 3 (each within the scatter of the next).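

In this assay, the amine nitrogen in a ring proves able to carry a change that moves the number beyond the scatter: 2-oxopropyl in place of cyclopropylsulfonyl gives a clear drop (a 6.9-fold lower number from compound 1 to compound 4 (0.84 log units; beyond the scatter)), and compound 4 also separates from the other two (a 9.1-fold lower number from compound 2 to compound 4 (0.96 log units; beyond the scatter); a 12-fold lower number from compound 3 to compound 4 (1.08 log units; beyond the scatter)). Cyclopropylsulfonyl, propargyl and 4-cyanobenzyl stayed within the scatter of one another, so the position looked flat, and compound 4 shows that it is not indifferent to the group placed there. Nothing available explains why this group lowers the number.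

From the compounds shown here alone, whether the carbonyl of 2-oxopropyl matters, or only the chain, stays open; a 2-hydroxypropyl group or a plain propyl chain on the same nitrogen would separate the two. A longer ketone chain such as 2-oxobutyl would show whether chain length matters.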